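The source may hold more compounds than are shown below. What is called first, only, known or untested is meant among the compounds shown, and "the series" means these compounds.

Compound 1 `Cc1ccccc1C(=O)OC1(C(=O)Nc2ccc([N+](=O)[O-])cc2)CCCCC1` gives 516 nM in a functional assay on MCF7 cells (Homo sapiens) for inhibition, read by MTT assay, with a stated time of 72 h; on this read-out lower numbers stand for stronger inhibition and higher numbers for weaker inhibition.
Compound 2 `O=C(OC1(C(=O)Nc2ccc([N+](=O)[O-])cc2)CCCCC1)c1ccccc1I` gives 619 nM in this assay.
Compound 3 `O=C(/C=C/c1ccccc1)OC1(C(=O)Nc2ccc([N+](=O)[O-])cc2)CCCCC1` gives 57.6 nM in this assay.

Compound 3 holds the lowest number of the three, set apart by a 9.0-fold lower number from compound 1 to compound 3 (0.95 log units; beyond the scatter) and an 11-fold lower number from compound 2 to compound 3 (1.03 log units; beyond the scatter), both beyond the scatter, while a 1.2-fold higher number from compound 1 to compound 2 (0.08 log units; within the scatter) leaves the two aryl esters close together. Compound 4 `CCC(=O)OC1(C(=O)Nc2ccc([N+](=O)[O-])cc2)CCCCC1` carries the change (ethyl in place of 2-phenylethenyl on a carbonyl carbon). For the measured compounds named here, no measured step exchanges an ester group for a plain chain, so only the two steps into compound 3 bear on it, and both point the same way: the 2-phenylethenyl ester is what separates compound 3 from the others. Taking it away is therefore expected to move this assay upward, toward weaker inhibition, by about a 12-fold higher number from compound 3 to compound 4 (1.08 log units; beyond the scatter). Compound 4 is estimated at 700 nM, with a range from 150 nM to 3000 nM.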

Compound 4, half-maximal inhibitory concentration: 14.1 nM
Estimate against measurement, compound 4: 50-fold (1.70 log units) above, outside the stated range (below it).
By their numbers in this assay, from the lowest: compound 4; then compound 3; then compounds 1 and 2 (each within the scatter of the next).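

In this assay, the 2-phenylethenyl group on this carbonyl carbon turns out not to be needed for a low number: ethyl goes further, with a 4.1-fold lower number from compound 3 to compound 4 (0.61 log units; beyond the scatter), and the gap to the aryl esters widens, with a 37-fold lower number from compound 1 to compound 4 (1.56 log units; beyond the scatter) and a 44-fold lower number from compound 2 to compound 4 (1.64 log units; beyond the scatter). Among these four compounds, then, no ring is required at this place. Nothing available explains why ethyl stands lowest. From the compounds shown here alone, whether methyl or a longer chain such as butyl would lower the number further stays open, as does the effect of an amine on that chain.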